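A larger group on the sulfur of a compound at the limit

The source may report more compounds than this note shows. Statements on the series, on what has been measured and on what is new or still open speak of the compounds shown alone.

In a functional assay on HT-29 cells (Homo sapiens) for inhibition, read by MTT assay, with a stated time of 48 h (a higher number here means a weaker inhibitor, a lower number a stronger inhibitor), compound 3 (`CCSc1nnc(-c2cc(OC)c(OC)c(OC)c2)n1-c1ccc(N(C)C)cc1`) gives > 60000 nM, which is a limit and not a number. Compound 1 (`CCSc1nnc(-c2cc(OC)c(OC)c(OC)c2)n1-c1ccc(OC)cc1`) gives > 60000 nM, which is also a limit. Compound 2 (`COc1ccc(-n2c(SCC(=O)c3ccc(OC)c(O)c3)nnc2-c2cc(OC)c(OC)c(OC)c2)cc1`) gives > 60000 nM, again a limit. Compound 3 therefore has no measured rank among its neighbours, and the whole picture so far is the limit of > 60000 nM in this assay, at which 3 of the 3 values shown sit.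

Compound 4 (`COc1cc(-c2nnc(SCc3ccc(C)cc3)n2-c2ccc(N(C)C)cc2)cc(OC)c1OC`) keeps the dimethylamino group of compound 3 and alters the side chain on the sulfur: 4-methylphenyl in place of methyl on a saturated chain carbon bound to a sulfur. In plainer terms, ethylsulfanyl gives way to (4-methylbenzyl)sulfanyl.

The closest measured change at this place is a step that the two limits leave unreadable from compound 1 to compound 2, where a large group also replaces methyl on the saturated chain carbon bound to the sulfur. The other measured change, a step that the two limits leave unreadable from compound 1 to compound 3, swaps methoxy for dimethylamino on an aromatic carbon. Neither has a readable size, so neither sets a size or direction for the new change.

The expectation is therefore little or no change, and the expected move is an at least 1.3-fold lower number from compound 3 to compound 4 (0.12 log units; that floor lies within the scatter). For compound 4 the estimated value is 45000 nM, within an expected range of 10000 nM to 60000 nM.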

Compound 4, half-maximal inhibitory concentration: 27500 nM
Beside the measured number, compound 4's estimate is 1.6-fold (0.21 log units) above it, and the stated range covers the measured number.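

In this assay, the side chain on the sulfur is now the first place in this set to give a step with a readable direction, an at least 2.1-fold lower number from compound 3 to compound 4 (0.33 log units; beyond the scatter), and that size is only a floor. The earlier steps shown here cannot be read because both ends of each sit at a limit: the limit of > 60000 nM in this assay, at which 3 of the 4 values shown sit. A larger group at this place is still not enough on its own, as compound 2, with (3-hydroxy-4-methoxyphenyl)carbonyl there, gives > 60000 nM, which is a limit and not a number.

As far as these compounds go, it remains open whether the number of compound 4 depends on the dimethylamino group, as the (4-methylbenzyl)sulfanyl side chain appears here only in compound 4 and never with the methoxy group of compound 1. It is also unclear what in the new group carries the step, and a plain benzyl, a longer alkyl chain or a chain ending in an amine on the sulfur would help separate the ring, its methyl and simple chain length.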